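Replacing cyclopropylamino in compound 3

The source may hold more compounds than are shown below. What is called first, only, known or untested is meant among the compounds shown, and "the series" means these compounds.

In a functional assay on MCF7 cells (Homo sapiens) for inhibition, read by fluorescence, with a stated time of 72 h (on this read-out higher numbers stand for weaker inhibition and lower numbers for stronger inhibition), compound 1 `CC(C)n1cnc2c(NC(=N)N)nc(N)nc21` gives 97200 nM and compound 2 `CC[C@H](N)COc1nc(NC(=N)N)c2ncn(C(C)C)c2n1` gives 16300 nM on a shared core. Compound 3 `CC(C)n1cnc2c(NC(=N)N)nc(NC3CC3)nc21` stands lowest of the three at 5400 nM and so shows the strongest inhibition so far. Compound 4 `CC(C)n1cnc2c(NC(=N)N)nc(N3CCC[C@@H]3CO)nc21` has 2-(hydroxymethyl)pyrrolidin-1-yl in place of cyclopropylamino on an aromatic carbon between two ring nitrogen atoms (2-(hydroxymethyl)pyrrolidin-1-yl in place of cyclopropylamino on an aromatic carbon). For the measured compounds named here, three measured steps bear on this place, all beyond the usual scatter: an 18-fold lower number from compound 1 to compound 3 (1.26 log units; beyond the scatter) with cyclopropyl in place of hydrogen on a nitrogen, a 6.0-fold lower number from compound 1 to compound 2 (0.78 log units; beyond the scatter) with 2-aminobutoxy in place of amino, and a 3.0-fold lower number from compound 2 to compound 3 (0.48 log units; beyond the scatter) with cyclopropylamino in place of 2-aminobutoxy. Going by the values given here, no tested compound carries the new ring, so the size of the change is uncertain. Among the compounds with values here, compound 2, the only tested compound with a larger group here, stands at 16300 nM and this points to a modest rise. The estimated step is a 2.2-fold higher number from compound 3 to compound 4 (0.35 log units; beyond the scatter) in this assay and means somewhat weaker inhibition. Compound 4 is estimated at 12000 nM with an expected range of 3500 nM to 40000 nM in this measurement.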

Compound 4, half-maximal inhibitory concentration: 20400 nM
Compound 4: the middle estimate sits 1.7-fold (0.23 log units) below what was measured, within the range that was stated.
By their numbers in this assay, from the lowest: compound 3; then compounds 2 and 4 (each within the scatter of the next); then compound 1.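

Putting 2-(hydroxymethyl)pyrrolidin-1-yl in place of cyclopropylamino gives a 3.8-fold higher number from compound 3 to compound 4 (0.58 log units; beyond the scatter) in this assay, so this second group larger than cyclopropylamino also gives weaker inhibition. The ring and the open 2-aminobutoxy chain cannot be told apart on this read-out, with a 1.3-fold higher number from compound 2 to compound 4 (0.10 log units; within the scatter), so swapping one for the other at this position makes no clear difference. The new ring still improves on the plain amino group, with a 4.8-fold lower number from compound 1 to compound 4 (0.68 log units; beyond the scatter), which leaves cyclopropylamino as the best of the four groups and shows that size alone does not set the order, since amino, the smallest group, gives the weakest inhibition.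

No information is available to explain these differences. From the compounds shown here alone, it remains open whether plain pyrrolidin-1-yl, without the hydroxymethyl arm, or a cyclobutylamino group would come closer to compound 3.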